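Chloro in Place of Methyl on the Ring of Compound 2

The source may hold more compounds than are shown below. What is called first, only, known or untested is meant among the compounds shown, and "the series" means these compounds.

The measured compounds in an assay on isolated protein for inhibition of Polyunsaturated fatty acid 5-lipoxygenase (Homo sapiens) (on this read-out higher numbers stand for weaker inhibition and lower numbers for stronger inhibition), are:
Compound 1 `Cc1ccccc1N1CCCC(=O)N1` gives 57000 nM.
Compound 2 `Cc1cccc(N2CCCC(=O)N2)c1` gives 3400 nM.
Compound 3 `CCc1ccccc1N1CCCC(=O)N1` gives 39000 nM.

Compound 2 gives the lowest number of the three, and its gaps to compound 3 and to compound 1 are both beyond the scatter, so it is the strongest inhibitor in this set. Compound 1 and compound 3 share the same substitution pattern on the aromatic ring and differ only in the chain; the step of a 1.5-fold lower number from compound 1 to compound 3 (0.16 log units; within the scatter) is small.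

Compound 4 `O=C1CCCN(c2cccc(Cl)c2)N1` is not yet measured. It differs from compound 2 by chloro in place of methyl on an aromatic carbon. Among the compounds with values here, none of the measured steps swaps one aromatic substituent for another; the only measured step, from compound 1 to compound 3, changes a saturated chain carbon and lies within the scatter. The data therefore give no direct guide for exchanging methyl for chloro on the ring, and the expectation is a step in this assay of about a 1.1-fold lower number from compound 2 to compound 4 (0.05 log units; within the scatter), that is no change beyond the scatter. Compound 4 is expected to give 3000 nM, with a range from 1000 nM to 10000 nM.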

Compound 4, half-maximal inhibitory concentration: 2500 nM
Compound 4: the middle estimate sits 1.2-fold (0.08 log units) above what was measured; the range from low to high includes it.
By their numbers in this assay, from the lowest: compounds 4 and 2 (each within the scatter of the next); then compounds 3 and 1 (each within the scatter of the next).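

In this assay, within the data shown here, the step of a 1.4-fold lower number from compound 2 to compound 4 (0.13 log units; within the scatter) is the first measured exchange of one ring substituent for another, and it places the numbers of the two compounds within the scatter of each other. Among these compounds, it shows that, on this aromatic carbon, meta to a group of 7 heavy atoms, chloro can take the place of methyl without a change beyond the scatter, something the only earlier step, a 1.5-fold lower number from compound 1 to compound 3 (0.16 log units; within the scatter), could not show, as that step changed a saturated chain carbon and left the ring substituent's identity untouched. No measured evidence is available to explain this result.

The compounds shown leave open whether a different group at this place, such as an amine, a carboxylic acid or a longer chain, would keep the number within the scatter of those of compound 2 and compound 4. They also leave open whether chloro in place of methyl would give a similar step on another carbon of the ring, as in the substitution pattern shared by compound 1 and compound 3.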